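Swapping an aryl group at the shared core: compound 4

The source may hold more compounds than are shown below. What is called first, only, known or untested is meant among the compounds shown, and "the series" means these compounds.

Compound 1 `O=Cc1ccc(-c2cn3ccnc3c(-c3ccc4ncn(C5CCCCC5)c4c3)n2)cc1`: 77.9%
Compound 2 `Fc1ccc(-c2cn3ccnc3c(-c3ccc4ncn(C5CCCCC5)c4c3)n2)cc1`: 33.4%
Compound 3 `c1cn2cc(-c3ccsc3)nc(-c3ccc4ncn(C5CCCCC5)c4c3)c2n1`: 29.2%

Three compounds share one core and differ only in the aryl group attached to it. In a functional assay on CCRF-CEM cells (Homo sapiens) for inhibition, read by sulforhodamine B assay, with a stated time of 48 h, tested at 10 uM (on this read-out higher numbers stand for more inhibition at the one concentration tested (going by the name of the read-out) and lower numbers for less inhibition), compound 1 gives 77.9%, compound 2 gives 33.4% and compound 3 gives 29.2%. Compound 3 has the lowest of the three numbers, though its gap to compound 2 lies within the scatter; only compound 1 stands clearly apart, as the step of a number 48.7 percentage points lower from compound 1 to compound 3 (beyond the scatter) shows.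

Compound 4 `Fc1ccccc1-c1cn2ccnc2c(-c2ccc3ncn(C4CCCCC4)c3c2)n1` is not yet measured. It differs from compound 3 by 2-fluorophenyl in place of thiophen-3-yl on an aromatic carbon. The measured step that bears most directly on this change is a number 4.2 percentage points lower from compound 2 to compound 3 (within the scatter), a swap between a fluorophenyl group and thiophen-3-yl that stayed within the scatter. Read in reverse, it suggests that returning from thiophen-3-yl to a fluorophenyl group changes little. Going by the values given here, no measured pair separates 2-fluorophenyl from 4-fluorophenyl, so the account rests on that single step alone.

Compound 4 is therefore expected to stay close to compound 3, with a step of a number 3.8 percentage points higher from compound 3 to compound 4 (within the scatter) that would not exceed the scatter. The estimate for compound 4 in this assay is 33%, within a range from 18% to 50%.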

Compound 4, a percentage reported as inhibition, at one concentration (the size of the read-out at that concentration, not a potency): 22.5%
The estimate for compound 4 lay 10.5 percentage points above the measured number; low and high end bracket the measured number.
By their numbers in this assay, from the lowest: compounds 4, 3 and 2 (each within the scatter of the next, the first and the last beyond it); then compound 1.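

In this assay, the swap from thiophen-3-yl to 2-fluorophenyl gives a number 6.7 percentage points lower from compound 3 to compound 4 (within the scatter), so these two groups cannot be told apart at this position, whereas the change from 4-fluorophenyl to 2-fluorophenyl gives a number 10.9 percentage points lower from compound 2 to compound 4 (beyond the scatter), the first measured sign that the place of the fluorine on the phenyl ring can matter here. Going by these compounds alone, the change from 4-formylphenyl gives a number 55.4 percentage points lower from compound 1 to compound 4 (beyond the scatter), so 4-formylphenyl remains the one group of the four that stands clearly apart. Nothing available gives a reason for any of these steps.

The compounds shown leave open whether a nitrile or a carboxylic acid in place of the formyl group would keep a number like that of 4-formylphenyl. They also leave open where 3-fluorophenyl would fall relative to the two fluorophenyl groups.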